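Trading a Chain Tip for Chlorine on the Amide

The source may report more compounds than this note shows. Statements on the series, on what has been measured and on what is new or still open speak of the compounds shown alone.

Three compounds share one core and are compared in a functional assay on HCT-116 cells (Homo sapiens) for inhibition, read by MTT assay, with a stated time of 48 h; a lower number here means a stronger inhibitor, a higher number a weaker inhibitor. Compound 1 `COc1ccc(CNc2cc(OC)c(OC)c(OC)c2)cc1[N+](=O)[O-]` gives 18200 nM in this assay. Compound 3 `COc1ccc(CNc2cc(OC)c(OC)c(OC)c2)cc1F` gives 32200 nM in this assay, and the step of a 1.8-fold higher number from compound 1 to compound 3 (0.25 log units; within the scatter) keeps the two on a level footing. Compound 2 `CCCCC(=O)N(Cc1ccc(OC)c(O)c1)c1cc(OC)c(OC)c(OC)c1`, which carries a butylcarbonyl on the amide nitrogen rather than a free amine, gives 170 nM in this assay, the lowest of the three numbers and far beyond the scatter from both others.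

Compound 4 `COc1ccc(CN(C(=O)CCCl)c2cc(OC)c(OC)c(OC)c2)cc1O` keeps the amide of compound 2 and changes only the chain on it: chloro in place of ethyl on a saturated chain carbon, two bonds along the chain from a carbonyl carbon

Among the measured compounds shown here, none of the measured steps touches this chain; the only step in hand, from compound 1 to compound 3, concerns a group on an aromatic carbon and stayed within the scatter, so it does not tell which way a change on the amide chain pulls. The amide with a short chain in compound 2 sits far from the free amines, so the expectation is that compound 4 stays in that region, with no step beyond the scatter, and the estimated step is a 1.5-fold higher number from compound 2 to compound 4 (0.17 log units; within the scatter). Compound 4 is therefore estimated at 250 nM, in a range from 60 nM to 1200 nM.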

Compound 4, half-maximal inhibitory concentration: 150 nM
Estimate against measurement, compound 4: 1.7-fold (0.22 log units) above; the range from low to high includes it.
By their numbers in this assay, from the lowest: compounds 4 and 2 (each within the scatter of the next); then compounds 1 and 3 (each within the scatter of the next).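

In this assay the step of a 1.1-fold lower number from compound 2 to compound 4 (0.05 log units; within the scatter) leaves the two amides level, so on this saturated chain carbon, two bonds along the chain from a carbonyl carbon, chloro in place of ethyl gives no change that can be told from the scatter. Among the compounds shown here, this is the first measured step on the amide chain, since the earlier step between compound 1 and compound 3 concerned a group on an aromatic carbon and said nothing about this chain. No measurement in hand accounts for why butyl and 2-chloroethyl read alike here.

Going by these compounds, what a longer chain, an amine or a carboxylic acid would do in the place of this chloro stays open, so this one swap cannot show how much variation the chain accepts. On these data alone, compound 2 and compound 4 both differ from compound 1 and compound 3 in more than one place, so how much of their distance from those two belongs to the amide alone also stays open.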